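The source may report more compounds than this note shows. Statements on the series, on what has been measured and on what is new or still open speak of the compounds shown alone.

For the measured compounds named here, compound 3 `CCc1ccccc1-n1nncc1CN1C(=O)C2(C(C#N)=C(N)Oc3c(N)cc4nc5ccccc5nc4c32)c2ccccc21` is the only member of the set with a number: in a functional assay on HepG2 cells (Homo sapiens) for antiproliferative activity, read by MTT assay, with a stated time of 48 h (a higher number here means a weaker inhibitor, a lower number a stronger inhibitor), compound 3 gives 17900 nM. Compound 1 `N#CC1=C(N)Oc2c(c3nc4ccccc4nc3c3ccccc23)C12C(=O)N(Cc1cnnn1-c1ccc(F)cc1)c1ccccc12` reaches only a limit, > 50000 nM. Compound 2 `Cc1cc(C)cc(-n2nncc2CN2C(=O)C3(C(C#N)=C(N)Oc4c3c3nc5ccccc5nc3c3ccccc43)c3ccccc32)c1` likewise reaches only a limit, > 50000 nM. The step that the two limits leave unreadable from compound 1 to compound 2 is therefore unreadable, and the limit of > 50000 nM in this assay, at which 2 of the 3 values shown sit, is where both of those values sit. Compound 4 `COc1ccc(-n2nncc2CN2C(=O)C3(C(C#N)=C(N)Oc4c(N)cc5nc6ccccc6nc5c43)c3ccccc32)cc1` differs from compound 3 in one place: 4-methoxyphenyl in place of 2-ethylphenyl on an aromatic nitrogen. Going by the values given here, no measured step bears on this change, since the only pair that varies the group on that ring nitrogen is unreadable and both of its members lack the amino group that compound 3 carries on its core. In this assay compound 4 is therefore expected near 20000 nM, with a range from 8000 nM to 50000 nM. The expected step of a 1.1-fold higher number from compound 3 to compound 4 (0.05 log units; within the scatter) is none beyond the scatter.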

Compound 4, half-maximal inhibitory concentration: > 50000 nM
Compound 4 ended at the assay's limit; the forecaster's own chance of this, stated with the estimate: 30%; middle value at least 2.5-fold (0.39 log units) away from the limit.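

With the amino-bearing core of compound 3 kept, the group on the aromatic nitrogen proves able to shift the result: 4-methoxyphenyl in place of 2-ethylphenyl gives an at least 2.7-fold higher number from compound 3 to compound 4 (0.44 log units; beyond the scatter) in this assay. For the compounds shown here, this is the only readable step at this position, and its size has only a lower bound. Compound 4 stands at a limit, not a number, and joins the others there: the limit of > 50000 nM in this assay, at which 3 of the 4 values shown sit.

The change alters both the group and its place on the phenyl ring, so the compounds shown cannot separate the two. From the compounds shown here alone, how 4-ethylphenyl, 2-methoxyphenyl or an amine on that ring would behave remains open.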